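Removing a methyl from a potent kinase inhibitor

A few compounds are considered here, and "the series" means these few. Any claim that something is new, unique, unknown or untested is made for them only; others in the source may bear on it.

Three compounds sharing a core have been characterised in an assay on isolated protein for inhibition of Rho-associated protein kinase 2 (Homo sapiens); a lower number here means a stronger inhibitor, a higher number a weaker inhibitor. Compound 1 `CC(C)Oc1ccc2c(c1)CC(c1nc3ccc(-c4ccnc(N)n4)cc3[nH]1)CO2` gives 296 nM, compound 2 `Cc1ccc2c(c1)CC(c1nc3ccc(-c4ccnc(N)n4)cc3o1)CO2` gives 78 nM, and compound 3 `Cc1[nH]ncc1-c1ccc2nc(C3COc4ccccc4C3)[nH]c2c1` gives 9 nM, the lowest of the three numbers, with both gaps to the others beyond the scatter. Compound 4 `c1ccc2c(c1)CC(c1nc3ccc(-c4cn[nH]c4)cc3[nH]1)CO2` has not yet been measured in this assay. It differs from compound 3 by hydrogen in place of methyl on an aromatic carbon. Among the compounds with values here, no measured pair isolates this change, so its size is unknown. A small loss or no change beyond the scatter is expected, giving the step of a 2.0-fold higher number from compound 3 to compound 4 (0.30 log units; within the scatter). Compound 4 is therefore estimated at 18 nM, within the range 5 nM to 60 nM.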

Compound 4, half-maximal inhibitory concentration: 27 nM
The estimate for compound 4 lay 1.5-fold (0.18 log units) below the measured number; the measured number falls inside the stated range.
By their numbers in this assay, from the lowest: compound 3; then compound 4; then compound 2; then compound 1.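

Within the data shown here, replacing 5-methyl-1H-pyrazol-4-yl with 1H-pyrazol-4-yl gives the first step in this assay that isolates a single change, a 3.0-fold higher number from compound 3 to compound 4 (0.48 log units; beyond the scatter), so the methyl on this aromatic carbon makes a modest but real difference. It is not indispensable, since compound 4 still gives 27 nM. No available evidence bears on what lies behind this step. Going by these compounds, what remains open is how an ethyl group or a chlorine atom at this place would compare with methyl. On these data alone, whether the step would be the same on another core also remains open.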